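The source may report more compounds than this note shows. Statements on the series, on what has been measured and on what is new or still open speak of the compounds shown alone.

Compound 1, `COc1cc(OC)c2c(=O)cc(/C=C/c3ccc([N+](=O)[O-])cc3)oc2c1`, in a functional assay on PC-3 cells (Homo sapiens) for antiproliferative activity, read by MTT assay, with a stated time of 12 h (a lower number here means a stronger inhibitor, a higher number a weaker inhibitor), gives > 40000 nM, which is a limit of the assay rather than a number.
Compound 2, `COc1cc(OC)c2c(=O)cc(/C=C/c3ccc(OCC4CC4)cc3)oc2c1`, in this assay gives > 40000 nM, again a limit.
Compound 3, `COc1cc(OC)c2c(=O)cc(/C=C/c3ccc(Cl)cc3)oc2c1`, in this assay gives > 40000 nM, also a limit.

Compound 3 therefore stands only at a limit, with no number of its own, and the two other values shown sit at the same limit: the limit of > 40000 nM in this assay, at which 3 of the 3 values shown sit. The step to the new compound 4, `COc1cc(OC)c2c(=O)cc(/C=C/c3ccc(C(F)(F)F)cc3)oc2c1`, is trifluoromethyl in place of chloro on an aromatic carbon. The measured steps that bear on the same aromatic carbon are a step that the two limits leave unreadable from compound 1 to compound 3 and a step that the two limits leave unreadable from compound 2 to compound 3, and both are unreadable in size, since each joins two limits. Across the three measured compounds, nitro, cyclopropylmethoxy and chloro all leave the value at the limit, so no direction and no size can be read for the step to compound 4. The expected step that the limit leaves unreadable from compound 3 to compound 4 is none beyond the scatter in any readable sense. Compound 4 is estimated at 60000 nM, within 20000 nM to 200000 nM, most likely reported again as a limit.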

Compound 4, half-maximal inhibitory concentration: > 40000 nM
Compound 4 gave a limit, no number (the forecaster's own chance of this, stated with the estimate: 85%); the middle value is on the limit's open side.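

Among the compounds shown here, compound 4 also gives only a limit, so no step among compound 1, compound 2, compound 3 and compound 4 can be read in size: the limit of > 40000 nM in this assay, at which 4 of the 4 values shown sit. The compounds shown leave open whether any group at this aromatic carbon would give in this assay a real number rather than a limit.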